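Nitrophenyl for bromophenyl on the second core

This account rests on a few compounds, and the source may have more. Where it says the series, first, only, none or still open, it means among the compounds named here.

Three compounds of this series have been run in a functional assay on HT-29 cells (Homo sapiens) for cytotoxicity, read by MTT assay, with a stated time of 72 h; on this read-out lower numbers stand for stronger inhibition and higher numbers for weaker inhibition. Compound 1 `COc1cc2c(Oc3ccc(NC(=O)c4nn(-c5ccccc5Br)c(=O)c5ccccc45)cc3F)ccnc2cc1OCCCN1CCN(C)CC1` gives 1190 nM in this assay. Compound 2 `COc1cc2c(Oc3ccc(NC(=O)c4nn(-c5ccc([N+](=O)[O-])cc5)c(=O)c5ccccc45)cc3F)ccnc2cc1OCCCN1CCN(C)CC1` differs from compound 1 by 4-nitrophenyl in place of 2-bromophenyl on an aromatic nitrogen. In this assay compound 2 gives 2560 nM. Compound 3 `COc1cc2c(Oc3ccc(NC(=O)c4nn(-c5ccccc5Br)c(=O)c5ccccc45)cc3F)ccnc2cc1OCCCN1CCC(C)CC1` differs from compound 1 by 4-methylpiperidin-1-yl in place of 4-methylpiperazin-1-yl on a saturated chain carbon, three bonds along the chain from an oxygen on an aromatic ring. In this assay compound 3 gives 950 nM. The first change gave a 2.2-fold higher number from compound 1 to compound 2 (0.33 log units; beyond the scatter). The second gave a 1.3-fold lower number from compound 1 to compound 3 (0.10 log units; within the scatter), so compounds 1 and 3 are not separated by this assay. Compound 3 and compound 2 stand furthest apart among the three, with compound 2 at the higher number.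

Compound 4 `COc1cc2c(Oc3ccc(NC(=O)c4nn(-c5ccc([N+](=O)[O-])cc5)c(=O)c5ccccc45)cc3F)ccnc2cc1OCCCN1CCC(C)CC1` is not yet measured. It differs from compound 3 by 4-nitrophenyl in place of 2-bromophenyl on an aromatic nitrogen. This is the same change as from compound 1 to compound 2, and the place where it sits reads the same in both pairs word for word; the two cores differ by 4-methylpiperidin-1-yl in place of 4-methylpiperazin-1-yl on a saturated chain carbon, three bonds along the chain from an oxygen on an aromatic ring. The change has been seen once so far, on the core of compound 1. Within the data shown here, for compound 4 the step is expected as a 2.2-fold higher number from compound 3 to compound 4 (0.34 log units; beyond the scatter) in this assay, because the only precedent is a 2.2-fold higher number from compound 1 to compound 2 (0.33 log units; beyond the scatter). The core change in the other pair gave a 1.3-fold lower number from compound 1 to compound 3 (0.10 log units; within the scatter), which leaves no sign that the two cores behave differently, though this rests on one pair. Compound 4 is estimated at 2100 nM in this assay, with a likely range from 1100 nM to 4200 nM.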

Compound 4, half-maximal inhibitory concentration: 2450 nM
Compound 4: the middle estimate sits 1.2-fold (0.07 log units) below what was measured; the measured number falls inside the stated range.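

In this assay the exchange of 2-bromophenyl for 4-nitrophenyl on the core of compound 3 gave a 2.6-fold higher number from compound 3 to compound 4 (0.41 log units; beyond the scatter), and this step cannot be told apart from the one on the core of compound 1: the same change on two cores in this assay, a 2.2-fold higher number (0.33 log units; beyond the scatter) from compound 1 to compound 2 and a 2.6-fold higher number (0.41 log units; beyond the scatter) from compound 3 to compound 4, 1.2-fold (0.08 log units) apart, within the scatter of two such steps.
The exchange of 4-methylpiperazin-1-yl for 4-methylpiperidin-1-yl, read on the two 4-nitrophenyl compounds, gave a 1.0-fold lower number from compound 2 to compound 4 (0.02 log units; within the scatter), which leaves that pair unseparated, as on the two 2-bromophenyl compounds: the same change on two cores in this assay, a 1.3-fold lower number (0.10 log units; within the scatter) from compound 1 to compound 3 and a 1.0-fold lower number (0.02 log units; within the scatter) from compound 2 to compound 4, 1.2-fold (0.08 log units) apart, within the scatter of two such steps.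
Within these four compounds the aryl exchange therefore carries from one core to the other without a detectable change in size, but this rests on two pairs in a single assay and shows neither why the step occurs nor whether it holds on any other core.

The compounds shown leave open whether an unsubstituted phenyl, a 4-bromophenyl or a 2-nitrophenyl on the same aromatic nitrogen would fall with the 2-bromophenyl or the 4-nitrophenyl compounds. They also leave open whether a morpholine or a dimethylamino group at the end of the chain would stay as close to the 4-methylpiperazin-1-yl and 4-methylpiperidin-1-yl compounds.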